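This account rests on a few compounds, and the source may have more. Where it says the series, first, only, none or still open, it means among the compounds named here.

Measured so far in an ADME assay on Vero cells (Chlorocebus sabaeus) for cytotoxicity, read by neutral red uptake, tested at 3150 ug/mL; a higher number here means a weaker effect of the compound at the concentration tested, a lower number a stronger effect:
compound 1 `O=C1CSC(c2c(Cl)cccc2Cl)N1CCN1CCCCC1` — 7%
compound 2 `O=C1CSC(c2cccc(O)c2)N1CCN1CCCCC1` — 11%
compound 3 `COc1cccc(C2SCC(=O)N2CCN2CCCCC2)c1` — 6%

All three numbers in this assay lie within the scatter of one another, so compound 2 is not separated from compound 1 or compound 3 in any meaningful way. Within the data shown here, the one measured step, a number 5 percentage points lower from compound 2 to compound 3 (within the scatter), is within the scatter.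

Compound 4 `O=C1CSC(c2ccc(Cl)cc2)N1CCN1CCCCC1` differs from compound 2 by 4-chlorophenyl in place of 3-hydroxyphenyl on a saturated ring carbon. Among the measured compounds shown here, no measured step exchanges the whole aromatic group; the step from compound 2 to compound 3 touches only the oxygen on that ring, and compound 1, which carries chlorine on its ring, sits in the same range as the others. Nothing here points to a step beyond the scatter, so for compound 4 a change of a number 3 percentage points lower from compound 2 to compound 4 (within the scatter) is expected, and compound 4 is estimated at 8% (range 2% to 16%).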

Compound 4, a percentage reported as activity, at one concentration (the size of the read-out at that concentration, not a potency): 11%
Compound 4: the middle estimate sits 3 percentage points below what was measured; the range from low to high includes it.
By their numbers in this assay, from the lowest: compounds 3, 1, 2 and 4 (each within the scatter of the next).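

In this assay, replacing the whole aromatic group on the saturated ring carbon gives no change at the digits printed from compound 2 to compound 4 (within the scatter) and so extends the earlier reading, which touched only the oxygen on that ring. At this position, 3-hydroxyphenyl with its hydrogen-bond donor and acceptor and 4-chlorophenyl with neither are not separated by this read-out. No available evidence bears on this result. Open, from the compounds shown here alone, is whether an amine or a carboxylic acid on the aromatic ring, or a longer chain in its place, would give a step beyond the scatter.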